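Two Limits and an Expected Third Result

A few compounds are considered here, and "the series" means these few. Any claim that something is new, unique, unknown or untested is made for them only; others in the source may bear on it.

Compound 1 `C#CCn1c(-c2ccc(C(=O)N/N=C/c3ccc[nH]3)cc2)nc2ccccc21`: >= 1000000 nM
Compound 2 `C#CCn1c(-c2ccc(C(=O)N/N=C/c3cccn3C)cc2)nc2ccccc21`: >= 100000 nM

In an assay on cells for inhibition of Amine oxidase [flavin-containing] A (Homo sapiens), read by fluorescence and Amplex Red, with stated times of 30 min and 5 min (on this read-out lower numbers stand for stronger inhibition and higher numbers for weaker inhibition), compound 1 gives only a limit, >= 1000000 nM. Compound 2 also gives only a limit, >= 100000 nM. Compound 2 therefore stands at the limit of >= 100000 nM in this assay, at which 1 of the 2 values shown sits, and the step that the two limits leave unreadable from compound 1 to compound 2 cannot be read. Compound 3 `C#CCn1c(-c2ccc(C(=O)N/N=C/c3ccc(Cl)cc3)cc2)nc2ccccc21` differs from compound 2 by 4-chlorophenyl in place of 1-methyl-1H-pyrrol-2-yl on a carbon with a double bond to nitrogen. Among the compounds with values here, the single measured step is unreadable, so no size or direction can be expected in this assay beyond the scatter. Compound 3 is expected to give 100000 nM, between 10000 nM and 1000000 nM. This means an expected step of a number no higher from compound 2 to compound 3 (the limit leaves the size open).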

Compound 3, half-maximal inhibitory concentration: >= 100000 nM
Compound 3 ended at the assay's limit; the forecaster's own chance of this, stated with the estimate: 80%; the middle value lies on the limit itself.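

Compound 3 adds only a limit in this assay, and the steps linking compound 1, compound 2 and compound 3 cannot be read. These compounds leave open whether any group on the carbon with a double bond to nitrogen gives a readable number rather than a limit.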